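Adding a 4-Chlorophenyl to an Amide Nitrogen

The compounds below may be only part of what the source reports. "The series", "measured", "known", "first", "only" and "open" are said of these compounds alone.

Measured so far:
compound 1, `N#C/C(=C\N1CCN(C(=O)c2ccco2)C1=S)C(N)=O`: 25400 nM
compound 2, `COc1cc(C(=O)N2CCN(C=O)C2=S)cc(OC)c1OC`: 36100 nM

Both were tested in a functional assay on NCI/ADR-RES cells (Homo sapiens) for inhibition, read by sulforhodamine B assay, with a stated time of 48 h; a higher number here means a weaker inhibitor of growth, a lower number a stronger inhibitor of growth. The numbers for compound 1 and compound 2 lie within the usual scatter of each other, so neither stands apart in this assay. Compound 3, `N#C/C(=C\N1CCN(C(=O)c2ccco2)C1=S)C(=O)Nc1ccc(Cl)cc1`, has not yet been measured. Its structural change from compound 1 is 4-chlorophenyl in place of hydrogen on an amide-type nitrogen. Among the measured compounds shown here, no measured pair shows this change, so its size is uncertain; a modest drop in the number, near the edge of the scatter, is expected as the step of a 2.1-fold lower number from compound 1 to compound 3 (0.33 log units; beyond the scatter). For compound 3 the estimate is 12000 nM, with a range from 3000 nM to 40000 nM.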

Compound 3, concentration for 50% growth inhibition: 28100 nM
Compound 3: middle estimate off by 2.3-fold (0.37 log units), on the low side; measured number inside the range.
By their numbers in this assay, from the lowest: compounds 1, 3 and 2 (each within the scatter of the next).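

In this assay, among the compounds shown here, the swap of hydrogen for 4-chlorophenyl on the amide-type nitrogen gives a 1.1-fold higher number from compound 1 to compound 3 (0.04 log units; within the scatter) and is the first step measured at this position. A bare hydrogen and a whole aromatic ring on this nitrogen therefore cannot be told apart in this growth read-out. No measured evidence bears on this result. From the compounds shown here alone, whether an unsubstituted phenyl, a methyl or a longer alkyl chain on the same nitrogen would separate from compound 1 remains open, and so does the effect of an amine on that ring.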